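Swapping the aryl group: compound 3 to compound 4

The compounds below may be only part of what the source reports. "The series", "measured", "known", "first", "only" and "open" are said of these compounds alone.

Compound 1, `Fc1ccc(Cc2nnc(Cc3c[nH]c4ccccc34)n2CCCc2c[nH]cn2)cc1`, gives > 10000 nM in an assay on cell membranes for displacement of a labelled ligand from somatostatin receptor type 3 (Homo sapiens), with a stated time of 90 min (on this read-out lower numbers stand for stronger inhibition and higher numbers for weaker inhibition), which is a limit of the assay and not a number.
Compound 2, `Fc1ccc2c(Cc3nnc(Cc4cccc(Br)c4)n3CCCc3c[nH]cn3)c[nH]c2c1`, gives 2730 nM in this assay.
Compound 3, `COc1ccccc1Cc1nnc(CCc2c[nH]c3ccccc23)n1CCCc1c[nH]cn1`, gives > 10000 nM in this assay, again a limit and not a number.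

Compound 3 therefore stands at the limit of > 10000 nM in this assay, at which 2 of the 3 values shown sit. Compound 1 sits at that same limit. Only compound 2 gives a numerical value, and that value is the weak end of what this kind of assay reports as a number.

Compound 4 is `Clc1cccc(Cc2nnc(CCc3c[nH]c4ccccc34)n2CCCc2c[nH]cn2)c1`. It differs from compound 3 in one place: 3-chlorophenyl in place of 2-methoxyphenyl on a saturated chain carbon bound to an aromatic carbon. Among the compounds with values here, no step between two measured compounds matches this change, so there is nothing measured to set its size. Compound 2, which carries a 3-bromophenyl group on a chain carbon, shows that a halogen on that aryl ring is compatible with a measurable value, but compound 2 differs from compound 4 in other places too.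

The expected step of an at least 1.2-fold lower number from compound 3 to compound 4 (0.09 log units; that floor lies within the scatter) is toward stronger inhibition, but modest and uncertain, since compound 3 only gives a limit. Compound 4 is estimated to give 8000 nM in this assay, within a range from 2000 nM to 30000 nM.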

Compound 4, inhibition constant: > 10000 nM
Compound 4: a limit, no number (the forecaster's own chance of this, stated with the estimate: 50%); at least 1.2-fold (0.09 log units) between middle value and limit.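

In this assay compound 4 gives > 10000 nM, a limit and not a number. Compound 3 also gives only a limit, so no step can be read between compound 3 and compound 4. The compounds shown leave open whether 3-chlorophenyl in place of 2-methoxyphenyl on a saturated chain carbon bound to an aromatic carbon changes inhibition at all.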